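This account rests on a few compounds, and the source may have more. Where it says the series, first, only, none or still open, it means among the compounds named here.

Measured in an ADME assay on A549 cells (Homo sapiens) for cytotoxicity, read by resazurin assay, with a stated time of 48 h; a higher number here means that more compound is tolerated, a lower number that less compound is tolerated:
- Compound 1 `CC(C)CNc1ccc(NC(=O)c2cc(Cl)ccc2O)c(Cl)c1`: 60000 nM
- Compound 2 `CC1(Nc2ccc(NC(=O)c3cc(Cl)ccc3O)c(Cl)c2)CCCC1`: 157000 nM
- Compound 3 `O=C(Nc1ccc(NCc2ccc(F)cc2)cc1Cl)c1cc(Cl)ccc1O`: 54400 nM

The three compounds differ only in the group on a nitrogen on an aromatic ring, and compound 3 carries 4-fluorobenzyl there. Its number cannot be told apart from that of compound 1, with a 1.1-fold lower number from compound 1 to compound 3 (0.04 log units; within the scatter). Compound 2 sits clearly higher, with a 2.9-fold lower number from compound 2 to compound 3 (0.46 log units; beyond the scatter).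

The next compound, compound 4 `O=C(Nc1ccc(NCc2ccc(Br)cc2)cc1Cl)c1cc(Cl)ccc1O`, keeps all of compound 3 except for one swap: bromo in place of fluoro on an aromatic carbon, para to a large group (bromo in place of fluoro on an aromatic carbon).

Within the data shown here, no measured step exchanges one halogen for another, so the evidence is indirect. The nearest guide is the pair of steps above, together with a 2.6-fold higher number from compound 1 to compound 2 (0.42 log units; beyond the scatter). Each of these replaces the whole group on that nitrogen, yet none is more than modest. A swap confined to one halogen is therefore expected to give no step beyond the scatter in this assay, and the data offer no firm direction.

The expected change is a 1.1-fold lower number from compound 3 to compound 4 (0.05 log units; within the scatter). For compound 4 the estimated value is 48000 nM, with an expected range of 24000 nM to 95000 nM.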

Compound 4, half-maximal cytotoxic concentration: 40900 nM
Beside the measured number, compound 4's estimate is 1.2-fold (0.07 log units) above it; the range from low to high includes it.
By their numbers in this assay, from the lowest: compounds 4, 3 and 1 (each within the scatter of the next); then compound 2.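

Swapping fluoro for bromo on the aromatic carbon para to a large group is the first exchange of one halogen for another in this series, and it gives a 1.3-fold lower number from compound 3 to compound 4 (0.12 log units; within the scatter) in this assay, so these two halogens cannot be told apart at this position. The 4-bromobenzyl group also cannot be told apart from isobutyl on the nitrogen, with a 1.5-fold lower number from compound 1 to compound 4 (0.17 log units; within the scatter) as the step between them, whereas 1-methylcyclopentyl remains clearly separate, with a 3.8-fold lower number from compound 2 to compound 4 (0.58 log units; beyond the scatter) as the step that shows it. Compounds 1, 3 and 4 therefore form one cluster and compound 2 stands apart from it, but no measurement among these results explains why the numbers fall this way.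

Two halogens at one position say little about groups of a different kind there, so a methoxy, a nitrile, an amine or a carboxylic acid on the same aromatic carbon could still move the number beyond the scatter. As far as these compounds go, it also remains open whether a chloro or an iodo at this position would fall within the same cluster, and whether a halogen swap would matter as little on a different ring of the core.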